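From 4-methylphenyl to pyridin-2-yl in compound 3

The source may hold more compounds than are shown below. What is called first, only, known or untested is meant among the compounds shown, and "the series" means these compounds.

In a functional assay on HCT-116 cells (Homo sapiens) for cytotoxicity, read by MTT assay, with a stated time of 72 h (on this read-out lower numbers stand for stronger inhibition and higher numbers for weaker inhibition), compound 1 `O=C1CS/C(=N\c2csc(-c3ccccc3)c2)N1` gives > 50000 nM, which is a limit of the assay and not a number. Compound 2 `O=C1N/C(=N/c2csc(-c3ccc(Cl)cc3)c2)S/C1=C\c1ccccc1` gives 11200 nM. Going by the values given here, compound 3 `Cc1ccc(/C=C2\S/C(=N\c3csc(-c4ccc(Cl)cc4)c3)NC2=O)cc1` gives 1000 nM, the lowest of the numbers so far, and the closest value to it belongs to compound 2.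

Compound 4 `O=C1N/C(=N/c2csc(-c3ccc(Cl)cc3)c2)S/C1=C\c1ccccn1` has not yet been measured. It differs from compound 3 at one place: pyridin-2-yl in place of 4-methylphenyl on a double-bonded chain carbon bound to a double-bonded ring carbon. In words, pyridin-2-yl stands in place of 4-methylphenyl on a double-bonded chain carbon bound to a double-bonded ring carbon.

Among the compounds with values here, one measured step bears on this change. Adding a methyl in place of hydrogen on an aromatic carbon gave an 11-fold lower number from compound 2 to compound 3 (1.05 log units; beyond the scatter), a large step beyond the scatter. Compound 4 lacks that methyl, so much of this gain is expected to be lost. Within the data shown here, no measured compound carries pyridin-2-yl, so the effect of the ring nitrogen remains open, and the range must stay wide. In this assay, the expected change is a large one towards a higher number, estimated as an 8.0-fold higher number from compound 3 to compound 4 (0.90 log units; beyond the scatter). The estimated value for compound 4 is 8000 nM, with an expected range from 2000 nM to 30000 nM.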

Compound 4, half-maximal inhibitory concentration: 21600 nM
Beside the measured number, compound 4's estimate is 2.7-fold (0.43 log units) below it; the range from low to high includes it.
By their numbers in this assay, from the lowest: compound 3; then compounds 2 and 4 (each within the scatter of the next). At a limit, above all of these: compound 1.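

In this assay, this position responds strongly to the choice of ring: a 22-fold higher number from compound 3 to compound 4 (1.33 log units; beyond the scatter). That step alone does not show that the ring nitrogen is what matters, since pyridin-2-yl also replaces the methyl-bearing ring of compound 3. The comparison with the plain phenyl ring separates these two changes, giving a 1.9-fold higher number from compound 2 to compound 4 (0.29 log units; within the scatter), so compound 2 and compound 4 cannot be ordered, and among these three compounds only the 4-methylphenyl group of compound 3 stands apart. Nothing measured here explains why this group differs from the other two rings.

From the compounds shown here alone, it remains open whether the lower number of compound 3 belongs to methyl alone or would also appear with another group on the phenyl ring, such as ethyl, methoxy or an amine. Going by these compounds, it also remains open whether a methyl placed on the pyridin-2-yl ring would bring the number back towards that of compound 3, which would show whether the two rings behave alike once both carry this group.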